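From pyridin-4-yl to 4-fluorophenyl in compound 4

This account rests on a few compounds, and the source may have more. Where it says the series, first, only, none or still open, it means among the compounds named here.

Compound 1 `CNC(=O)c1cc(C(=O)N[C@H]2[C@@H]3COC[C@@H]32)cc2c1OC[C@H]2c1cccc2[nH]ccc12`, compound 2 `CNC(=O)c1cc(C(=O)N[C@H]2[C@@H]3COC[C@@H]32)cc2c1OC[C@H]2c1ccccc1` and compound 3 `CNC(=O)c1cc(C(=O)N[C@H]2[C@@H]3COC[C@@H]32)cc2c1OC[C@H]2c1ccncc1` share one core and differ only in the group on a saturated ring carbon. In a physicochemical assay for solubility (on this read-out lower numbers stand for lower solubility and higher numbers for higher solubility), compound 1 gives >= 171 ug/mL, which is a limit. Compound 2 gives >= 165 ug/mL, also a limit. Compound 3 gives >= 184 ug/mL, again a limit, so compound 3 has no exact number and cannot be ranked against the other two.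

Compound 4 `CNC(=O)c1cc(C(=O)N[C@H]2[C@@H]3COC[C@@H]32)cc2c1OC[C@H]2c1ccc(F)cc1` carries 4-fluorophenyl in place of pyridin-4-yl on a saturated ring carbon. The nearest evidence is a step that the two limits leave unreadable from compound 2 to compound 3. The other two measured steps are a step that the two limits leave unreadable from compound 1 to compound 2 and a step that the two limits leave unreadable from compound 1 to compound 3. None of the three gives a size to carry over, so no step beyond the scatter is expected in this assay, in either direction, and another limit is the likely report. The estimated step, an at least 1.0-fold lower number from compound 3 to compound 4 (0.03 log units; that floor lies within the scatter), is expected to stay within the scatter. For compound 4 the estimated value is 170 ug/mL, with an expected range of 90 ug/mL to 200 ug/mL.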

Compound 4, solubility: >= 176 ug/mL
Compound 4 ended at the assay's limit; the forecaster's own chance of this, stated with the estimate: 75%; middle value at least 1.0-fold (0.01 log units) away from the limit.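

In this assay compound 4 gives >= 176 ug/mL, which is a limit. The steps linking compound 4 with compound 1, compound 2 and compound 3 cannot be read. The compounds shown leave open whether the group on the saturated ring carbon shifts this read-out at all: all four values are limits.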